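Trifluoromethoxy for trifluoromethyl on a methylbenzimidazole triaryl

The source may report more compounds than this note shows. Statements on the series, on what has been measured and on what is new or still open speak of the compounds shown alone.

Compound 1 `Oc1cccc2[nH]c(-c3ccc(-c4ccc(-c5ccc(C(F)(F)F)cc5)cc4)cc3)nc12` gives 3180 nM in a functional assay on DWD cells (Homo sapiens) for inhibition, read by sulforhodamine B assay; a higher number here means a weaker inhibitor of growth, a lower number a stronger inhibitor of growth. Compound 2 `Oc1cccc2[nH]c(-c3ccc(-c4ccc(-c5ccc(OC(F)(F)F)cc5)cc4)cc3)nc12` differs from it by trifluoromethoxy in place of trifluoromethyl on an aromatic carbon and gives 3100 nM in this assay; the step is a 1.0-fold lower number from compound 1 to compound 2 (0.01 log units; within the scatter). Compound 3 `Cc1ccc2[nH]c(-c3ccc(-c4ccc(-c5ccc(C(F)(F)F)cc5)cc4)cc3)nc2c1` carries a different core, the difference being (5-methyl-1H-benzimidazol-2-yl in place of 4-hydroxy-1H-benzimidazol-2-yl on an aromatic carbon), and gives 38200 nM in this assay; the step is a 12-fold higher number from compound 1 to compound 3 (1.08 log units; beyond the scatter), so compound 3 stands at the highest number of the three measured compounds.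

Compound 4 `Cc1ccc2[nH]c(-c3ccc(-c4ccc(-c5ccc(OC(F)(F)F)cc5)cc4)cc3)nc2c1` has not been measured. It differs from compound 3 by trifluoromethoxy in place of trifluoromethyl on an aromatic carbon. This is the same change as that from compound 1 to compound 2, at the same place, and it occurs twice among the compounds shown. The expectation for compound 4 rests on compound 1 and compound 2, where the change gave a 1.0-fold lower number from compound 1 to compound 2 (0.01 log units; within the scatter) in this assay. Compound 4 is therefore expected to show a step of a 1.0-fold lower number from compound 3 to compound 4 (0.00 log units; within the scatter) in this assay. Compound 4 is estimated at 38000 nM in this assay, with a range from 15000 nM to 95000 nM expected.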

Compound 4, concentration for 50% growth inhibition: 41100 nM
The estimate for compound 4 lay 1.1-fold (0.03 log units) below the measured number; low and high end bracket the measured number.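

On the core of compound 3, trifluoromethoxy in place of trifluoromethyl gives a 1.1-fold higher number from compound 3 to compound 4 (0.03 log units; within the scatter) in this assay, and this step agrees with the one on the core of compound 1: the same change on two cores in this assay, a 1.0-fold lower number (0.01 log units; within the scatter) from compound 1 to compound 2 and a 1.1-fold higher number (0.03 log units; within the scatter) from compound 3 to compound 4, 1.1-fold (0.04 log units) apart, within the scatter of two such steps. The core change, 5-methyl-1H-benzimidazol-2-yl in place of 4-hydroxy-1H-benzimidazol-2-yl, also carries over between the two end groups, giving a 13-fold higher number from compound 2 to compound 4 (1.12 log units; beyond the scatter) in this assay: the same change on two cores in this assay, a 12-fold higher number (1.08 log units; beyond the scatter) from compound 1 to compound 3 and a 13-fold higher number (1.12 log units; beyond the scatter) from compound 2 to compound 4, 1.1-fold (0.04 log units) apart, within the scatter of two such steps. Across these four compounds, the two changes therefore combine without any sign that one alters the size of the other, but this rests on only two cores and two end groups in a single assay, and it shows neither that the end-group change would stay this small on another core nor why the core change is large.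

The compounds shown leave open whether the core step belongs to the hydroxy group, the methyl group or both. They also leave open how an amine, a carboxylic acid or a longer chain would behave in place of trifluoromethyl on the same aromatic carbon.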